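A few compounds are considered here, and "the series" means these few. Any claim that something is new, unique, unknown or untested is made for them only; others in the source may bear on it.

- compound 1 (`CCCCC(C#CC(=O)OC)O/C=C/C(=O)OC`): 250 nM
- compound 2 (`CCCCCCC(C#CC(=O)O)O/C=C/C(=O)OC`): > 100000 nM
- compound 3 (`C#CC(O/C=C/C(=O)OC)c1ccccc1`): 26000 nM

In a functional assay on HBL-100 cells (Homo sapiens) for antiproliferative activity, read by sulforhodamine B assay, with a stated time of 48 h (a higher number here means a weaker inhibitor of growth, a lower number a stronger inhibitor of growth), compound 1 has the lower of the two actual numbers (250 nM), and compound 3 lies higher (26000 nM), a gap beyond the scatter. Compound 2 gives only a limit of the assay (> 100000 nM).

The next compound to be measured is compound 4 (`COC(=O)C#CC(CCc1ccccc1)O/C=C/C(=O)OC`). Its difference from compound 1 is a single change (phenyl in place of ethyl on a saturated chain carbon, three bonds along the chain from an oxygen on an unsaturated carbon and a triple-bonded carbon): phenyl in place of ethyl on a saturated chain carbon, three bonds along the chain from an oxygen on an unsaturated carbon and a triple-bonded carbon.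

For the measured compounds named here, no measured pair differs in one place only, so no measured step can serve as a guide. Going by the values given here, the expectation therefore starts from compound 1 (250 nM), with compound 3 (26000 nM) as the only other number available. In this assay a moderate step towards a higher number is expected, meaning a somewhat weaker inhibitor of growth, and it may not clear the scatter by much. The estimated change is (a 2.4-fold higher number from compound 1 to compound 4 (0.38 log units; beyond the scatter)). For compound 4 the expected value is 600 nM, with an estimated range from 120 nM to 4000 nM.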

Compound 4, concentration for 50% growth inhibition: 2600 nM
Compound 4: middle estimate off by 4.3-fold (0.64 log units), on the low side; the measured number falls inside the stated range.
By their numbers in this assay, from the lowest: compound 1; then compound 4; then compound 3. At a limit, above all of these: compound 2.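

In this assay, the saturated chain carbon three bonds along from the oxygen on an unsaturated carbon and the triple-bonded carbon proves sensitive to what it carries. For the compounds shown here, this is the first comparison that differs in one place only, and phenyl in place of ethyl gives a 10-fold higher number from compound 1 to compound 4 (1.02 log units; beyond the scatter). The end of this chain is therefore not a free site for change with the rest of the structure held constant, although no measurement shown accounts for a step of this size.

This single step cannot separate the loss of the ethyl from the arrival of the phenyl, and a cyclohexyl or a phenyl carrying a methoxy group on the same saturated chain carbon would show whether the aromatic ring itself sets the number. Going by these compounds, it also remains open how this chain change behaves with a different group in place of the methyl ester on the triple-bonded carbon, such as an amide.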